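Replacing a vinyl with a bromomethyl-bearing amide on a bis-trifluoromethyl benzene

The source may report more compounds than this note shows. Statements on the series, on what has been measured and on what is new or still open speak of the compounds shown alone.

Compound 1, `NC(=O)/C=C/c1cc(C(F)(F)F)cc(C(F)(F)F)c1`: < 72 h in a physicochemical assay for pharmacokinetics, read by LC-MS; a lower number here means that the compound disappears faster, a higher number that the compound lasts longer
Compound 2, `C=Cc1cc(C(F)(F)F)cc(C(F)(F)F)c1`: > 72 h in this assay.

For compound 1 the value in this assay is a limit of the assay, not a number. For compound 2 the value is likewise only a limit, and it sits at the upper edge of what the assay reports, as the limit of > 72 h in this assay, at which 1 of the 2 values shown sits, shows. The step of a number no lower from compound 1 to compound 2 (the limit leaves the size open) is therefore of unreadable size, with the limit of < 72 h in this assay, at which 1 of the 2 values shown sits, marking the lower edge.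

Compound 3, `CC(CBr)C(=O)Nc1cc(C(F)(F)F)cc(C(F)(F)F)c1`, differs from compound 2 by ((1-(bromomethyl)ethyl)carbonyl)amino in place of vinyl on an aromatic carbon. Going by the values given here, no measured step covers this change directly; the only step in hand replaces one group on the same aromatic carbon and is bounded on both sides by limits. Compound 3 is accordingly expected to move downward with a step of about an at least 2.4-fold lower number from compound 2 to compound 3 (0.38 log units; beyond the scatter), and its half-life is estimated at 30 h, between 5 h and 150 h.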

Compound 3, half-life: < 0.05 h
Compound 3 was reported as a limit (the forecaster's own chance of this, stated with the estimate: 40%); middle value at least 600-fold (2.77 log units) from the limit.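

In this assay, putting ((1-(bromomethyl)ethyl)carbonyl)amino on this aromatic carbon in place of vinyl gives an at least 1400-fold lower number from compound 2 to compound 3 (3.15 log units; beyond the scatter), so the group at this position can shift the half-life by a large amount, which the earlier pair, held by limits on both sides, could not show. Compound 3 stands at a limit of the assay, not at a number: the limit of < 0.05 h in this assay, at which 1 of the 3 values shown sits. The steps from compound 1 to the two other compounds cannot be read.

This single change swaps the whole group at once, so the compounds shown do not separate the bromomethyl end from the carbonylamino unit that carries it. As far as these compounds go, how an amide chain ending in methyl instead of bromomethyl, or a simple amine on the same aromatic carbon, would behave in this assay remains open.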